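The source may hold more compounds than are shown below. What is called first, only, known or untested is meant among the compounds shown, and "the series" means these compounds.

Working notes on the series. In a functional assay on L6 cells (Rattus norvegicus) for inhibition, read by scintillation counting, with a stated time of 3 h (on this read-out higher numbers stand for weaker inhibition and lower numbers for stronger inhibition), compound 1 `COc1ccc(CNC(=O)c2nc(-c3ccc(F)cc3)n(CC[C@@H](O)C[C@@H](O)CC(=O)O)c2C2CC2)cc1` gives 6400 nM. Compound 2 `CN(C)S(=O)(=O)c1ccc(CNC(=O)c2nc(-c3ccc(F)cc3)n(CC[C@@H](O)C[C@@H](O)CC(=O)O)c2C2CC2)cc1` is recorded in this assay only as a limit of the assay, > 100000 nM, which is the limit of > 100000 nM in this assay, at which 1 of the 2 values shown sits. Compound 2 therefore stands at the upper end of the numbers shown, the one measured step being an at least 15-fold higher number from compound 1 to compound 2 (1.19 log units; beyond the scatter) with dimethylsulfamoyl in place of methoxy on an aromatic carbon.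

Compound 3 `COc1ccccc1CNC(=O)c1nc(-c2ccc(F)cc2)n(CC[C@@H](O)C[C@@H](O)CC(=O)O)c1C1CC1` is not yet measured. It differs from compound 2 by 2-methoxyphenyl in place of 4-(dimethylsulfamoyl)phenyl on a saturated chain carbon bound to an amide-type nitrogen. Among the compounds with values here, the only measured step that bears on this change is an at least 15-fold higher number from compound 1 to compound 2 (1.19 log units; beyond the scatter), which runs in the opposite sense: methoxy was replaced by dimethylsulfamoyl and the number rose sharply. Compound 3 returns to a methoxy-bearing ring, now as 2-methoxyphenyl, so a large step downward in this assay is expected, toward the region of compound 1 at 6400 nM. The expected step from compound 2 to compound 3 is an at least 10-fold lower number from compound 2 to compound 3 (1.00 log units; beyond the scatter). Compound 3 is estimated at 10000 nM in this assay, within 3000 nM to 40000 nM.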

Compound 3, half-maximal inhibitory concentration: 10700 nM
The estimate for compound 3 lay 1.1-fold (0.03 log units) below the measured number, within the range that was stated.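

In this assay, the return to a methoxy-bearing ring gives an at least 9.3-fold lower number from compound 2 to compound 3 (0.97 log units; beyond the scatter), so the lower number seen with compound 1 is not confined to 4-methoxyphenyl at this place. Compound 2 is held only as a limit of the assay, so this step has a bound and no exact size: the limit of > 100000 nM in this assay, at which 1 of the 3 values shown sits. Moving the methoxy group, with 2-methoxyphenyl in place of 4-methoxyphenyl, gives a 1.7-fold higher number from compound 1 to compound 3 (0.22 log units; within the scatter), so the two methoxy-bearing rings cannot be told apart on this read-out.

The compounds shown leave open whether an unsubstituted phenyl ring, or a ring bearing a dimethylamino group or a carboxylic acid, would fall with compound 1 and compound 3 or with compound 2. Also open, going by these compounds, is what a longer chain between the amide nitrogen and the ring would do.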